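Dichlorobenzyl to Fluorobenzyl on a Shared Diamine Core

A few compounds are considered here, and "the series" means these few. Any claim that something is new, unique, unknown or untested is made for them only; others in the source may bear on it.

Measured compounds:
compound 1 `Nc1cc(N)c2nc(-c3ccccc3)c(NCc3ccc(Cl)c(Cl)c3)nc2c1`: 75900 nM
compound 2 `CCOC(=O)[C@H](CCC(=O)O)NC(=O)c1ccc(Sc2nc3cc(N)cc(N)c3nc2-c2ccccc2)cc1`: < 100000 nM
compound 3 `COc1cc(CNc2nc3cc(N)cc(N)c3nc2-c2ccccc2)cc(OC)c1OC`: 34700 nM

Of the compounds shown here, three sharing the same core have been tested in a functional assay on M14 cells (Homo sapiens) for inhibition, read by sulforhodamine B assay, with a stated time of 48 h; a lower number here means that less compound is tolerated, a higher number that more compound is tolerated. Compound 1 gives 75900 nM, the highest of the two numbers obtained. Compound 3 gives 34700 nM, a lower number that lies beyond the scatter of the assay. For compound 2 only a limit is reported, < 100000 nM, so it gives no number; this is the point noted as the limit of < 100000 nM in this assay, at which 1 of the 3 values shown sits.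

Compound 4 `Nc1cc(N)c2nc(-c3ccccc3)c(NCc3ccc(F)cc3)nc2c1` has not yet been measured in this assay. Its difference from compound 1 is a single replacement: 4-fluorophenyl in place of 3,4-dichlorophenyl on a saturated chain carbon bound to a nitrogen on an aromatic ring. Among the compounds with values here, no measured pair in this set carries that change, so no step can be read from the data. The account therefore expects the step from compound 1 to compound 4, a 1.2-fold higher number from compound 1 to compound 4 (0.07 log units; within the scatter), to stay within the scatter, with a slight lean toward a higher number. On that basis compound 4 is estimated at 90000 nM, within a range from 40000 nM to 200000 nM.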

Compound 4, concentration lethal to 50% of the cells: < 100000 nM
Compound 4 gave a limit, no number; the forecaster's own chance of this, stated with the estimate: 40%; the middle value is on the limit's open side.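

Compound 4 gives < 100000 nM, a limit and not a number, so no step can be read between compound 1 and compound 4: the limit of < 100000 nM in this assay, at which 2 of the 4 values shown sit. The compounds shown leave open how 4-fluorophenyl compares with 3,4-dichlorophenyl on the shared core.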